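Benzyl for Iodophenyl on the Amine of Compound 2

The source may hold more compounds than are shown below. What is called first, only, known or untested is meant among the compounds shown, and "the series" means these compounds.

Measured so far:
compound 1 `CCCCOC1=C(C(=O)c2ccccc2)C(c2ccc(Br)cc2)N(CCCn2ccnc2)C1=O` — 18500 nM
compound 2 `O=C(C1=C(Nc2ccc(I)cc2)C(=O)N(CCCn2ccnc2)C1c1ccc(Br)cc1)c1ccccc1` — 24500 nM

In a functional assay on A549 cells (Homo sapiens) for antiproliferative activity, read by MTT assay, with a stated time of 72 h (a lower number here means a stronger inhibitor, a higher number a weaker inhibitor), compound 1 gives 18500 nM. Compound 2 gives 24500 nM in this assay, and on these two numbers it carries the higher one, though the gap a 1.3-fold higher number from compound 1 to compound 2 (0.12 log units; within the scatter) is within the scatter. Compound 3 `O=C(C1=C(NCc2ccccc2)C(=O)N(CCCn2ccnc2)C1c1ccc(Br)cc1)c1ccccc1` differs from compound 2 in one place: benzyl in place of 4-iodophenyl on an amine nitrogen. For the measured compounds named here, the only measured step, a 1.3-fold higher number from compound 1 to compound 2 (0.12 log units; within the scatter), replaces a butoxy by a (4-iodophenyl)amino group on the ring carbon and so touches the amine end of this position, but not the exchange of an aryl for a benzyl group on that nitrogen; it offers no direct guide. Given that neither measured compound shows a large step, compound 3 is expected to land close to compound 2, with the expected step of a 1.0-fold higher number from compound 2 to compound 3 (0.01 log units; within the scatter) not clearly beyond the scatter in either direction. Compound 3 is therefore estimated at 25000 nM, within a range of 8000 nM to 70000 nM.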

Compound 3, half-maximal inhibitory concentration: 52800 nM
Estimate against measurement, compound 3: 2.1-fold (0.32 log units) below; the measured number falls inside the stated range.
By their numbers in this assay, from the lowest: compounds 1 and 2 (each within the scatter of the next); then compound 3.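

In this assay, for the compounds shown here, the exchange of 4-iodophenyl for benzyl on the amine nitrogen gives the first step at this position that lies beyond the scatter, a 2.2-fold higher number from compound 2 to compound 3 (0.33 log units; beyond the scatter), whereas the earlier exchange of butoxy for (4-iodophenyl)amino stayed within it, a 1.3-fold higher number from compound 1 to compound 2 (0.12 log units; within the scatter). Measured against butoxy, benzylamino also gives a higher number, a 2.9-fold higher number from compound 1 to compound 3 (0.46 log units; beyond the scatter), so among these three groups the double-bonded ring carbon does not treat all substituents alike, and the identity of the group on the amine nitrogen matters more than the earlier pair suggested. The leaving and entering groups hold the same count of heavy atoms and one six-membered aromatic ring each, so the step arises without a change in those counts, and no measured evidence bears on what lies behind it.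

From the compounds shown here alone, whether the step follows the loss of iodine or the change from an aryl to a benzyl group stays open, and a phenylamino or a 4-iodobenzylamino group on the same carbon would separate the two. Also open, going by these compounds, is how a longer chain on the nitrogen, such as phenethyl, would read in this assay.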